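Methoxycarbonyl to carbamoyl repeated on two cores

This account rests on a few compounds, and the source may have more. Where it says the series, first, only, none or still open, it means among the compounds named here.

Measured compounds, with the inhibition constant in an assay (Rattus norvegicus) for inhibition of Fatty-acid amide hydrolase 1 (Homo sapiens); on this read-out higher numbers stand for weaker inhibition and lower numbers for stronger inhibition:
compound 1 `COC(=O)c1cccc(-c2cnc(C(=O)CCCCCCc3ccccc3)o2)c1`: 12 nM
compound 2 `NC(=O)c1cccc(-c2cnc(C(=O)CCCCCCc3ccccc3)o2)c1`: 6 nM
compound 3 `COC(=O)c1cnc(C(O)CCCCCCc2ccccc2)o1`: 2000 nM

Compound 1 and compound 2 share one core. Compound 3 stands on a different core, and the difference between the two cores is not broken down here. Compound 3 gives the highest number of the three in this assay; its gap to compound 1 and its gap to compound 2 are both beyond the usual scatter.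

Within the first core the single change is amino in place of methoxy on a carbonyl carbon It produced a step of a 2.0-fold lower number from compound 1 to compound 2 (0.30 log units; within the scatter), so on this core the change is not resolved from repeat-measurement noise.

Compound 4 `NC(=O)c1cnc(C(O)CCCCCCc2ccccc2)o1` is not yet measured. It arises from compound 3 by amino in place of methoxy on a carbonyl carbon The place reads the same word for word as in the pair above, so this is the same change, made a second time, now on the core of compound 3. Among the compounds here the change occurs twice in all.

The expectation for compound 4 rests solely on the step from compound 1 to compound 2 being small; nothing here shows the change acting differently on the other core. For compound 4 the expected step is a 2.0-fold lower number from compound 3 to compound 4 (0.30 log units; within the scatter), taken from the size of a 2.0-fold lower number from compound 1 to compound 2 (0.30 log units; within the scatter). Compound 4 is therefore estimated at 1000 nM in this assay, with a likely range from 350 nM to 3000 nM.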

Compound 4, inhibition constant: 25000 nM
Compound 4: middle estimate off by 25-fold (1.40 log units), on the low side; measured number outside the range, above it.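

In this assay the change from methoxycarbonyl to carbamoyl does not carry over from one core to the other: on the core of compound 3 it gives a 13-fold higher number from compound 3 to compound 4 (1.10 log units; beyond the scatter) and so sets a step beyond the scatter against one within it, as the comparison of the two steps confirms: the same change on two cores in this assay, a 2.0-fold lower number (0.30 log units; within the scatter) from compound 1 to compound 2 and a 13-fold higher number (1.10 log units; beyond the scatter) from compound 3 to compound 4, 25-fold (1.40 log units) apart, beyond the scatter of two such steps. For this series, then, the small step on the core of compound 1 is no safe guide to the size of the same change on the core of compound 3, and each core needs its own reading for this change. The result does not show which structural difference between the two cores is responsible, and with a single pair on each core it gives no rule for any further core.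

The compounds shown leave open which part of the difference between the two cores governs the step, a question that single changes between the cores could separate. They also leave open how a carboxylic acid or an N-methyl amide at the same carbonyl carbon would read on each core, and so whether the step on the core of compound 3 is peculiar to the amino group.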